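Ester oxygen to sulfur at the carbamate of compound 3

The compounds below may be only part of what the source reports. "The series", "measured", "known", "first", "only" and "open" are said of these compounds alone.

Compound 1 `CC(C)(C)OC(=O)N1CCC(Oc2cccc3c2CCN3c2ccc(S(C)(=O)=O)cc2)CC1` gives 92% in a functional assay on CHO-K1 cells with Glucose-dependent insulinotropic receptor (Homo sapiens) as the target, read by a luciferase reporter, with a stated time of 5 h; a higher number here means a larger maximal response, a lower number a smaller maximal response.
Compound 2 `COC(=O)N1CCC(Oc2ncnc3c2CCN3c2ccc(S(C)(=O)=O)cc2F)CC1` gives 119% in this assay.
Compound 3 `CC(C)COC(=O)N1CCC(Oc2ncnc3c2CCN3c2ccc(S(C)(=O)=O)cc2F)CC1` gives 94% in this assay.

Compound 3 holds the second highest of the three maximal responses. Among the measured compounds shown here, its nearest neighbour is compound 1, whose value lies within the scatter of that of compound 3, so the two cannot be told apart; compound 2 stands beyond the scatter above it, and the one measured step, a number 25 percentage points lower from compound 2 to compound 3 (beyond the scatter), is the single change that bears on what follows. Compound 4 `CC(C)SC(=O)N1CCC(Oc2ncnc3c2CCN3c2ccc(S(C)(=O)=O)cc2F)CC1` differs from compound 3 at the carbonyl carbon of the carbamate: isopropylsulfanyl in place of isobutoxy on a carbonyl carbon. For the measured compounds named here, that step exchanges one small alkyl group for another and the oxygen for a sulfur, a change of the same part of the molecule as the measured step, but not of the same kind, and the data hold no example of it. The measured step being modest, a step of at most modest size in this assay is expected here, and most likely one that stays within the scatter. The expected step is a number 4 percentage points lower from compound 3 to compound 4 (within the scatter). Compound 4 is therefore expected to reach about 90%, with a range from 70% to 112%.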

Compound 4, largest response reached (reported as percent of maximum), in percent of the reference or control that the assay uses: 138%
Compound 4: middle estimate off by 48 percentage points, on the low side; the measured number lies above the stated range.
By their numbers in this assay, from the lowest: compounds 1 and 3 (each within the scatter of the next); then compound 2; then compound 4.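

Among the compounds shown here, at this carbonyl carbon, the only earlier step, a number 25 percentage points lower from compound 2 to compound 3 (beyond the scatter) in this assay, had gone downward, yet isopropylsulfanyl in place of isobutoxy gives a number 44 percentage points higher from compound 3 to compound 4 (beyond the scatter) and reverses that fall. The same group also exceeds methoxy, with a number 19 percentage points higher from compound 2 to compound 4 (beyond the scatter), so replacing methoxy here does not always lower the maximal response, and the response at this position can rise past that of the methoxy compound. No measurement available here accounts for this rise.

The change replaces the linking oxygen with sulfur and shortens the chain in one step, so the compounds shown cannot separate the contribution of each. Isopropoxy or isobutylsulfanyl on the same carbonyl carbon would divide the two changes, and it remains open how an isopropylamino group there would compare.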